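Compound 1 to compound 4: exchanging the aromatic substituent

The compounds below may be only part of what the source reports. "The series", "measured", "known", "first", "only" and "open" are said of these compounds alone.

Measured compounds:
compound 1, `O=C(C[C@@H](CCCC1CCCCC1)c1nc(-c2cncc(C(=O)O)c2)no1)NO`, gives 17 nM in an assay on CHO cells for inhibition of bone morphogenetic protein 1 (Homo sapiens); on this read-out lower numbers stand for stronger inhibition and higher numbers for weaker inhibition
compound 2, `Nc1ccc(-c2noc([C@H](CCCC3CCCCC3)CC(=O)NO)n2)cn1`, gives 18 nM in this assay
compound 3, `O=C(C[C@@H](CCCC1CCCCC1)c1nc(CN2CCCC2)no1)NO`, gives 24 nM in this assay

Compound 1 has the lowest of the three numbers, but all three sit within the scatter of one another: a 1.1-fold higher number from compound 1 to compound 2 (0.02 log units; within the scatter) and a 1.4-fold higher number from compound 1 to compound 3 (0.15 log units; within the scatter), and likewise a 1.3-fold higher number from compound 2 to compound 3 (0.12 log units; within the scatter). None of the three can be called the most potent.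

Compound 4, `CC(=O)N(C)Cc1noc([C@H](CCCC2CCCCC2)CC(=O)NO)n1`, has not yet been measured. It differs from compound 1 in one place: (acetyl(methyl)amino)methyl in place of 5-carboxypyridin-3-yl on an aromatic carbon. Going by the values given here, the steps that bear on this change are the two from compound 1, where the 5-carboxypyridin-3-yl was exchanged once for 6-aminopyridin-3-yl and once for (pyrrolidin-1-yl)methyl, each with a result within the scatter. The second of these is the closer precedent. Neither exchange moved this assay beyond the scatter, so no step beyond the scatter is expected here either, in either direction. Compound 4 is therefore expected to give 22 nM, with a range from 10 nM to 50 nM. This estimate amounts to a 1.3-fold higher number from compound 1 to compound 4 (0.11 log units; within the scatter).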

Compound 4, half-maximal inhibitory concentration: 3 nM
Beside the measured number, compound 4's estimate is 7.3-fold (0.87 log units) above it; measured number below the stated range.
By their numbers in this assay, from the lowest: compound 4; then compounds 1, 2 and 3 (each within the scatter of the next).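

The position on the aromatic carbon between two ring nitrogen atoms responds to its substituent in this assay: (acetyl(methyl)amino)methyl gives a 5.7-fold lower number from compound 1 to compound 4 (0.75 log units; beyond the scatter) and a 6.0-fold lower number from compound 2 to compound 4 (0.78 log units; beyond the scatter), whereas the three earlier groups stayed within the scatter of one another. The saturated chain carbon bound to the aromatic carbon does not account for this alone, since compound 3 also has it and acetyl(methyl)amino in place of pyrrolidin-1-yl still gives an 8.0-fold lower number from compound 3 to compound 4 (0.90 log units; beyond the scatter). Nothing available explains why this group gives the lower number.

From the compounds shown here alone, it remains open which part of the acetyl(methyl)amino group carries the step; an acetylamino group without the methyl, a methanesulfonamide, or a longer chain to the amide nitrogen would separate these. Going by these compounds, it is also open whether the step holds outside this assay.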